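This account rests on a few compounds, and the source may have more. Where it says the series, first, only, none or still open, it means among the compounds named here.

Working notes on the series. In an ADME assay on HeLa cells (Homo sapiens) for cytotoxicity (on this read-out higher numbers stand for lower toxicity in this test and lower numbers for higher toxicity in this test), compound 2 `CCCc1cc(-c2cn([C@H]3C[C@H](OC(C)=O)[C@@H](COC(C)=O)O3)c(=O)[nH]c2=O)on1` gives 3000 nM. Compound 1 `CCCCCCCCc1cc(-c2cn([C@H]3C[C@H](O)[C@@H](CO)O3)c(=O)[nH]c2=O)on1` gives 3000 nM in this assay. Compound 3 `CCCCCc1cc(-c2cn([C@H]3C[C@H](OC(C)=O)[C@@H](COC(C)=O)O3)c(=O)[nH]c2=O)on1` gives 3000 nM in this assay. Compound 2 therefore stands level with compounds 1 and 3, all within the scatter of one another, so none is set apart. Going by the values given here, the only single-point step measured so far is no change at the digits printed from compound 2 to compound 3 (within the scatter). Compound 4 `CC(=O)OC[C@H]1O[C@@H](n2cc(-c3cc(-c4ccccc4)no3)c(=O)[nH]c2=O)C[C@@H]1OC(C)=O` remains to be measured. Its change from compound 2: phenyl in place of propyl on an aromatic carbon. That measured step bears on it only loosely, as it concerns ethyl in place of hydrogen on a chain rather than phenyl in place of propyl, but nothing in the series has moved this assay, so no step beyond the scatter is expected. Compound 4 is expected at 3000 nM, ranging from 1500 nM to 6000 nM. The expected step of no change at the digits printed from compound 2 to compound 4 (within the scatter) is estimated to lie within the scatter.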

Compound 4, half-maximal cytotoxic concentration: 3000 nM
Compound 4: middle estimate and measured number agree at the digits printed; low and high end bracket the measured number.
By their numbers in this assay, from the lowest: compounds 1, 2, 3 and 4 (each within the scatter of the next).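

At the aromatic carbon next to the ring nitrogen, an aromatic ring now stands where earlier compounds carried saturated chains. In this assay, phenyl in place of propyl gives no change at the digits printed from compound 2 to compound 4 (within the scatter), and phenyl in place of pentyl gives no change at the digits printed from compound 3 to compound 4 (within the scatter). This position therefore tolerates both chains and a six-membered aromatic ring of carbon only, with no step beyond the scatter. On these data alone, whether an amine or a carboxylic acid at this carbon would shift the read-out remains open. No measurement on hand accounts for this flat read-out.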